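The compounds below may be only part of what the source reports. "The series", "measured", "known", "first", "only" and "open" are said of these compounds alone.

Working notes on the series in an ADME assay on MT4 cells (Homo sapiens) for cytotoxicity; a higher number here means that more compound is tolerated, a lower number that less compound is tolerated. Among the measured compounds shown here, compound 2 (`FC(F)(F)c1cccc(NC(=S)Nc2ccc(Cl)cc2)c1`) gives 6800 nM, the lowest number of the three measured so far. Compound 3 (`COc1cccc(NC(=S)Nc2cccc(C(F)(F)F)c2)c1`) gives 26000 nM and compound 1 (`CC[C@H]1CC[C@H](c2ccc(NC(=S)Nc3cccc(C(F)(F)F)c3)cc2)CC1`) gives 39000 nM. Both numbers are higher than that of compound 2.

The step under consideration leads to compound 4 (`Fc1ccccc1NC(=S)Nc1cccc(C(F)(F)F)c1`), with 2-fluorophenyl in place of 4-chlorophenyl on an amide-type nitrogen.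

One measured step connects to compound 2: a 5.7-fold lower number from compound 1 to compound 2 (0.76 log units; beyond the scatter), with chloro in place of 4-ethylcyclohexyl on an aromatic carbon. For the measured compounds named here, that step is modest in size and beyond the scatter, but no measured step exchanges chloro for fluoro, so it offers only a rough guide to size. Going by the values given here, compound 2 is the only measured compound carrying chloro, and compound 4 loses that group. With so few compounds, this is weak evidence, and it suggests only a movement towards the higher numbers in this assay. The expected step, smaller than the measured one, is a 2.1-fold higher number from compound 2 to compound 4 (0.31 log units; beyond the scatter).

For compound 4 the estimated value is 14000 nM, with an expected range of 6000 nM to 35000 nM.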

Compound 4, half-maximal cytotoxic concentration: 47000 nM
Compound 4: middle estimate off by 3.4-fold (0.53 log units), on the low side, and the stated range ends below it.
By their numbers in this assay, from the lowest: compound 2; then compounds 3, 1 and 4 (each within the scatter of the next).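

In this assay, replacing 4-chlorophenyl with 2-fluorophenyl on the amide-type nitrogen gives a 6.9-fold higher number from compound 2 to compound 4 (0.84 log units; beyond the scatter) and so moves the number beyond the scatter, although both groups have the same heavy-atom count, one six-membered aromatic ring of carbon only, no hydrogen-bond donors or acceptors and no net charge. The low number of compound 2 therefore does not extend to every halogen-bearing phenyl at this place: it appears with 4-chlorophenyl but not with 2-fluorophenyl, and compound 4 instead falls with compounds 3 and 1, which lie within the scatter of one another in the ordering of the series. Nothing available on this series accounts for the size or direction of this step.

This change alters the halogen and its ring position together, so the compounds shown cannot separate the two; 2-chlorophenyl and 4-fluorophenyl on the same nitrogen would divide the step into those two parts. On these data alone, it also remains open whether the low number of compound 2 is specific to chloro, or whether a phenyl carrying an amine or a carboxylic acid at the same ring position would give a similar number.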